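This account rests on a few compounds, and the source may have more. Where it says the series, first, only, none or still open, it means among the compounds named here.

Compound 1 `CNc1nc(NC2(C#N)CCCCC2)nc(-n2cnc(C)n2)n1` gives, in an ADME assay on microsomes from liver (Rattus norvegicus) for metabolic stability (on this read-out higher numbers stand for fast clearance and lower numbers for slow clearance), a value of > 276 mL/min/kg, which is a limit of the assay rather than a number. Compound 2 `CNc1nc(NC2(C#N)CCCCC2)nc(N(C)C)n1` gives 276 mL/min/kg. Compound 3 `CNc1nc(NC2(C#N)CCCCC2)nc(-n2cnc(C#N)n2)n1` gives 210 mL/min/kg.

Compound 1 therefore stands at the upper edge of what this assay reports: the limit of > 276 mL/min/kg in this assay, at which 1 of the 3 values shown sits. Compound 4 `CNc1nc(Cl)nc(NC2(C#N)CCCCC2)n1` differs from it by a small change, (chloro in place of 3-methyl-1H-1,2,4-triazol-1-yl on an aromatic carbon). Two measured steps start from compound 1 and swap out the same group: a number no higher from compound 1 to compound 2 (the limit leaves the size open) and an at least 1.3-fold lower number from compound 1 to compound 3 (0.11 log units; that floor lies within the scatter). Neither moves the number beyond the scatter. A similar outcome is expected here, namely an at least 1.1-fold lower number from compound 1 to compound 4 (0.04 log units; that floor lies within the scatter). Compound 4 is thus estimated at 250 mL/min/kg, within 120 mL/min/kg to 276 mL/min/kg, with a fair chance of again reaching only a limit.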

Compound 4, clearance: 867 mL/min/kg
Compound 4: the middle estimate sits 3.5-fold (0.54 log units) below what was measured, outside the stated range (above it).
By their numbers in this assay, from the lowest: compounds 3 and 2 (each within the scatter of the next); then compound 4.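

Putting chloro at this position gives a 4.1-fold higher number from compound 3 to compound 4 (0.62 log units; beyond the scatter), and a 3.1-fold higher number from compound 2 to compound 4 (0.50 log units; beyond the scatter). The earlier swap here gave only a 1.3-fold lower number from compound 2 to compound 3 (0.12 log units; within the scatter), so the number at this position does respond to the group, and chloro stands apart from dimethylamino and 3-cyano-1H-1,2,4-triazol-1-yl. Compound 1 holds only a limit, so steps from it cannot be read: the limit of > 276 mL/min/kg in this assay, at which 1 of the 4 values shown sits.

Going by these compounds, whether the higher number belongs to chloro alone or to other small groups here remains open. A methoxy group, a hydroxyl or a plain hydrogen at this position could separate those two readings.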